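The compounds below may be only part of what the source reports. "The series", "measured", "known", "first", "only" and "open" are said of these compounds alone.

Measured so far in an assay on LtK cells with ATP-sensitive inward rectifier potassium channel 11 (Homo sapiens) as the target; on this read-out lower numbers stand for an effect already at smaller amounts and higher numbers for an effect only at larger amounts of compound:

- compound 1 `CCC(=O)Nc1c(C(O)(C(F)(F)F)C(F)(F)F)ccc2ccccc12`: compound 1 gives 15 nM
- compound 2 `CC(C)C(=O)Nc1c(C(O)(C(F)(F)F)C(F)(F)F)ccc2ccccc12`: compound 2 gives 6630 nM
- compound 3 `C/C=C/C(=O)Nc1c(C(O)(C(F)(F)F)C(F)(F)F)ccc2ccccc12`: compound 3 gives 72 nM

Compound 3 stands second highest of the three numbers. Its nearest neighbour is compound 1, with a 4.8-fold higher number from compound 1 to compound 3 (0.68 log units; beyond the scatter); its furthest is compound 2, with a 92-fold lower number from compound 2 to compound 3 (1.96 log units; beyond the scatter).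

The next compound is compound 4 `Cc1ccccc1C(=O)Nc1c(C(O)(C(F)(F)F)C(F)(F)F)ccc2ccccc12`. Relative to compound 3 the change is 2-methylphenyl in place of prop-1-en-1-yl on a carbonyl carbon.

Among the measured compounds shown here, two measured steps bear on this. The first, a 440-fold higher number from compound 1 to compound 2 (2.65 log units; beyond the scatter), shows that a change at the carbon attached to the carbonyl carbon can move the number a great deal in this assay. The second, a 4.8-fold higher number from compound 1 to compound 3 (0.68 log units; beyond the scatter), shows that exchanging ethyl for prop-1-en-1-yl on the carbonyl carbon gives only a modest rise. For the measured compounds named here, no measured step exchanges a chain for a ring on the carbonyl carbon, so the size of this particular move is not covered by the series. The ring carbon that joins the carbonyl carries a second neighbour in the 2-methylphenyl group, which puts this change closer to the first step than to the second. A step of a 21-fold higher number from compound 3 to compound 4 (1.32 log units; beyond the scatter) in this assay is therefore expected, towards a higher number. For compound 4 the estimate is 1500 nM, with a range of 150 nM to 15000 nM.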

Compound 4, half-maximal effective concentration: 5550 nM
Compound 4: middle estimate off by 3.7-fold (0.57 log units), on the low side, within the range that was stated.
By their numbers in this assay, from the lowest: compound 1; then compound 3; then compounds 4 and 2 (each within the scatter of the next).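

Among the compounds shown here, the 2-methylphenyl group is the first aromatic ring on the carbonyl carbon in this assay, and it gives a much higher number than either of the two unbranched chains: against prop-1-en-1-yl (a 77-fold higher number from compound 3 to compound 4 (1.89 log units; beyond the scatter)) and against ethyl (a 370-fold higher number from compound 1 to compound 4 (2.57 log units; beyond the scatter)). Against isopropyl the ring shows no separation (a 1.2-fold lower number from compound 2 to compound 4 (0.08 log units; within the scatter)), so across these four compounds the higher numbers go with branching at the carbon bound to the carbonyl carbon, in compound 2 and compound 4, and no compound shown goes against this. Nothing available gives a reason for this grouping, and the numbers alone cannot supply one.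

Still open, from the compounds shown here alone, is how much of the rise belongs to the ring itself and how much to its methyl, which a plain phenyl group on the carbonyl carbon would separate. Also open, going by these compounds, is whether branching alone tracks the number, which a cyclopropyl group, a tert-butyl group or a longer chain such as butyl would test, and whether an amine or a carboxylic acid on the chain is tolerated at this position.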